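A few compounds are considered here, and "the series" means these few. Any claim that something is new, unique, unknown or untested is made for them only; others in the source may bear on it.

Measured so far: compound 1 `CCc1nn2c(-c3c(COC)cc(OC)cc3OC)cccc2c1N(CC1CCOCC1)CC1CC1` with 120 nM; compound 2 `CCc1nn2c(-c3c(C)cc(OC)cc3OC)cccc2c1N(CC1CCOCC1)CC1CC1` with 40 nM; compound 3 `CCc1nn2c(-c3c(C)cc(C)cc3OC)cccc2c1N(CC1CC1)CC1CCCO1` with 34 nM.

All three were run in an assay on HEK293 cells for displacement of a labelled ligand from corticotropin-releasing factor receptor 1 (Homo sapiens), read by scintillation counting, with a stated time of 2 h; a lower number here means a stronger inhibitor, a higher number a weaker inhibitor. Compound 3 has the lowest of the three numbers, but compound 2 stands within the scatter of it, so the two cannot be ranked; only compound 1 lies clearly higher. Among the compounds with values here, the one single-place step recorded, a 3.0-fold lower number from compound 1 to compound 2 (0.48 log units; beyond the scatter), concerns a group on the aryl ring and gives no guidance on the amine side of the shared core.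

Compound 4 `CCc1nn2c(-c3c(C)cc(C)cc3OC)cccc2c1N(CC1CCOCC1)CC1CC1` keeps the aryl ring of compound 3 and changes the amine side: oxan-4-yl in place of oxolan-2-yl on a saturated chain carbon bound to a nitrogen on an aromatic ring. Within the data shown here, no measured pair differs at exactly this place. The closest hint is compound 2, which carries the same amine side as compound 4 and, despite a further difference on the aryl ring, gives a number within the scatter of compound 3. Among the measured compounds shown here, with no step bearing directly on the change, the expectation in this assay is a step of about a 1.0-fold higher number from compound 3 to compound 4 (0.01 log units; within the scatter), that is, no movement beyond the scatter. The estimate for compound 4 is therefore 35 nM, within a range of 15 nM to 80 nM.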

Compound 4, half-maximal inhibitory concentration: 22 nM
Estimate against measurement, compound 4: 1.6-fold (0.20 log units) above, and the stated range covers the measured number.
By their numbers in this assay, from the lowest: compounds 4, 3 and 2 (each within the scatter of the next); then compound 1.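

In this assay, oxan-4-yl in place of oxolan-2-yl on a saturated chain carbon bound to a nitrogen on an aromatic ring gives a 1.5-fold lower number from compound 3 to compound 4 (0.19 log units; within the scatter), so at this position the six-membered ring and the five-membered ring cannot be told apart in these two compounds. The other new pair gives a 1.8-fold lower number from compound 2 to compound 4 (0.26 log units; within the scatter), which shows that methyl in place of methoxy on an aromatic carbon of the aryl ring also leaves the number within the usual scatter of repeated measurements. Nothing available here explains why either change has so small an effect.

Both rings compared at the amine side contain one oxygen, so the compounds shown leave open what happens when a plain cyclohexyl ring, with carbon in place of that oxygen, or a piperidin-4-yl ring, with an amine nitrogen there, takes the same place. They also leave open whether the match between oxolan-2-yl and oxan-4-yl would hold with the aryl ring of compound 1, since that ring is paired here only with oxan-4-yl.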